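Swapping 1-phenylethyl for (4-fluorophenyl)amino on a carbonyl carbon

This account rests on a few compounds, and the source may have more. Where it says the series, first, only, none or still open, it means among the compounds named here.

Of the compounds shown here, two built on a shared core have been measured so far. In a functional assay on A2780 cells (Homo sapiens) for cytotoxicity (on this read-out higher numbers stand for weaker inhibition and lower numbers for stronger inhibition), compound 1 (`CC(=O)Nc1ncc(SCc2ncc(C(C)C)o2)s1`) gives 200 nM. In the same test compound 2 (`C[C@@H](C(=O)Nc1ncc(SCc2ncc(C(C)(C)C)o2)s1)c1ccccc1`) gives 900 nM. That is the higher of the two numbers, and the gap between them lies beyond the usual scatter of repeat measurements, so compound 2 is the weaker inhibitor of this pair.

Compound 3 (`CC(C)(C)c1cnc(CSc2cnc(NC(=O)Nc3ccc(F)cc3)s2)o1`) has not been measured yet. It differs from compound 2 in one place: (4-fluorophenyl)amino in place of 1-phenylethyl on a carbonyl carbon. In short, (4-fluorophenyl)amino stands in place of 1-phenylethyl on a carbonyl carbon, and each of the two groups holds one six-membered aromatic ring of carbon only. Among the compounds with values here, no measured pair shows what such a swap does, so the expectation starts from compound 2 at 900 nM. In this assay no change beyond the scatter is expected, with an estimated 1.3-fold lower number from compound 2 to compound 3 (0.11 log units; within the scatter). For compound 3 the estimated value is 700 nM, with an expected range from 200 nM to 2500 nM.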

Compound 3, half-maximal inhibitory concentration: 900 nM
Compound 3: the middle estimate sits 1.3-fold (0.11 log units) below what was measured, and the stated range covers the measured number.
By their numbers in this assay, from the lowest: compound 1; then compounds 2 and 3 (each within the scatter of the next).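

Within the data shown here, replacing 1-phenylethyl with (4-fluorophenyl)amino on a carbonyl carbon gives, in this assay, no change at the digits printed from compound 2 to compound 3 (within the scatter) and this is the first measured exchange at this position. The entering group differs in several counted ways: it brings a nitrogen, a fluorine and a hydrogen-bond donor, and the defined stereocentre of 1-phenylethyl is gone, yet the read-out stays level, so on this assay the position accepts that combined change while a six-membered aromatic ring of carbon only stays in place. No measurement available here accounts for why the two groups read alike.

As far as these compounds go, the nitrogen and the fluorine enter together in this single step, so what each does alone remains open, and a plain phenylamino group, with the same nitrogen but no fluorine, would begin to separate them. Also open, from the compounds shown here alone, is whether an aromatic ring is required on this carbonyl carbon at all, a question that a morpholine or a longer alkyl chain in the same place could address.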